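Fluorine for Chlorine on the Benzyl Arm: Cytotoxicity Outlook

The compounds below may be only part of what the source reports. "The series", "measured", "known", "first", "only" and "open" are said of these compounds alone.

Of the compounds shown here, three have been measured and a fourth awaits its number. Compound 1 `O=C1/C(=C/c2ccccc2F)CN(Cc2cn(Cc3ccccc3F)nn2)C/C1=C\c1ccccc1F` and compound 2 `O=C1/C(=C/c2ccccc2F)CN(Cc2cn(Cc3cccc(Cl)c3)nn2)C/C1=C\c1ccccc1F` are built on one shared core, while compound 3 `Cc1ccc(/C=C2\CN(Cc3cn(Cc4cccc(Cl)c4)nn3)C/C(=C\c3ccc(C)cc3)C2=O)cc1` rests on a different core; the difference between the core of compound 2 and the core of compound 3 is not broken down here. In an ADME assay on HEK293 cells (Homo sapiens) for cytotoxicity, read by MTT assay, with a stated time of 24 h (on this read-out higher numbers stand for weaker inhibition and lower numbers for stronger inhibition), compound 1 gives 41200 nM. Compound 2 gives 33100 nM in this assay. Compound 3 gives 73500 nM in this assay, which is the highest of the three numbers and lies beyond the scatter only against compound 2.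

Among the compounds with values here, the single structural change within the set that has been measured on both sides runs from compound 2 to compound 1: 2-fluorophenyl in place of 3-chlorophenyl on a saturated chain carbon bound to an aromatic nitrogen. That change produced a 1.2-fold higher number from compound 2 to compound 1 (0.10 log units; within the scatter), a step that does not rise above the noise of repeated measurement.

Compound 4 `Cc1ccc(/C=C2\CN(Cc3cn(Cc4ccccc4F)nn3)C/C(=C\c3ccc(C)cc3)C2=O)cc1` is compound 3 carrying the same change: 2-fluorophenyl in place of 3-chlorophenyl on a saturated chain carbon bound to an aromatic nitrogen. The two places are described in the same words, so this is the same change, now made on the other core. Within the data shown here, the expectation for compound 4 rests on the one measured instance, which gave a 1.2-fold higher number from compound 2 to compound 1 (0.10 log units; within the scatter) from compound 2 to compound 1, so a similarly small step is expected, namely a 1.2-fold higher number from compound 3 to compound 4 (0.06 log units; within the scatter). Compound 4 is therefore estimated at 85000 nM in this assay, with a range from 45000 nM to 160000 nM, and the measurement will tell whether the second core follows the first.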

Compound 4, half-maximal inhibitory concentration: > 100000 nM
Compound 4 ended at the assay's limit; the forecaster's own chance of this, stated with the estimate: 25%; middle value at least 1.1-fold (0.07 log units) from the limit.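

Compound 4 gave no number in this read-out, only a limit of the assay: the limit of > 100000 nM in this assay, at which 1 of the 4 values shown sits. Read against compound 3 in this assay, the change from 3-chlorobenzyl to 2-fluorobenzyl gives an at least 1.3-fold higher number from compound 3 to compound 4 (0.13 log units; that floor lies within the scatter), and that figure is only a floor, so the real size of the step on this core remains unknown and could be small or much larger. What this shows is that the change, made on a second core, did not bring the number down, but it does not show that the change carries over from one core to the other at the same size, nor that its size depends on the core: the same change on two cores in this assay, a 1.2-fold higher number (0.10 log units; within the scatter) from compound 2 to compound 1 and an at least 1.3-fold higher number (0.13 log units; that floor lies within the scatter) from compound 3 to compound 4; the limit leaves it open whether they differ.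

Within the data shown here, with only two pairs, each built on its own core and one of them ending at a limit, the series offers no general rule for this change, and a compound on the core of compound 3 that reads below the limit would be needed to give the step a firm size. The compounds shown also carry only 3-chlorophenyl and 2-fluorophenyl at this place, on a saturated chain carbon bound to an aromatic nitrogen, so they leave open what an amine, a carboxylic acid or a longer chain there would do to the number on either core.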